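Extending the side chain on the shared core

A few compounds are considered here, and "the series" means these few. Any claim that something is new, unique, unknown or untested is made for them only; others in the source may bear on it.

Compound 2 `CO/N=C\c1ccc(-c2nn(Cc3ccccc3)c3ccccc23)cc1` stands at the limit in a functional assay on cells (Platelet, Homo sapiens) for inhibition (a lower number here means a stronger inhibitor, a higher number a weaker inhibitor), giving > 10000 nM, which is a limit of the assay and not a number. Compound 1 `NC(=O)c1ccc(-c2nn(Cc3ccccc3)c3ccccc23)cc1` likewise gives > 10000 nM, also a limit. Going by the values given here, the only measured step, a step that the two limits leave unreadable from compound 1 to compound 2, is therefore unreadable, as the limit of > 10000 nM in this assay, at which 2 of the 2 values shown sit, shows. Compound 3 `CCOC(=O)/C=C/c1ccc(-c2nn(Cc3ccccc3)c3ccccc23)cc1` carries a group of 7 heavy atoms (5 carbon, 2 oxygen; no ring) in place of a group of 4 heavy atoms (2 carbon, 1 nitrogen, 1 oxygen; no ring), on an aromatic carbon. Among the compounds with values here, no measured step bears on this change, and with both known values at the limit no direction can be drawn, so the step that the limit leaves unreadable from compound 2 to compound 3 is expected only as a guess. Compound 3 is estimated at 15000 nM, between 2000 nM and 100000 nM, most likely again reported as a limit.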

Compound 3, half-maximal inhibitory concentration: > 10000 nM
Compound 3: no number, only a limit (the forecaster's own chance of this, stated with the estimate: 70%); the middle value is on the limit's open side.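

No step among compound 1, compound 2 and compound 3 can be read, because all three stand at a limit and not at a number: the limit of > 10000 nM in this assay, at which 3 of the 3 values shown sit.

The compounds shown leave open whether any side chain on the shared core gives a measurable value in this assay.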